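Bromo for fluoro on the methoxy compound

The compounds below may be only part of what the source reports. "The series", "measured", "known", "first", "only" and "open" are said of these compounds alone.

In a functional assay on MCF7 cells (Homo sapiens) for antiproliferative activity, read by MTT assay, with a stated time of 48 h (on this read-out lower numbers stand for stronger inhibition and higher numbers for weaker inhibition), compound 1 `Fc1ccc(-c2nn(-c3ccccc3)cc2-c2nc3cc(F)ccc3[nH]2)cc1` gives 950 nM, compound 2 `Fc1ccc(-c2nn(-c3ccccc3)cc2-c2nc3cc(Br)ccc3[nH]2)cc1` gives 3210 nM and compound 3 `COc1ccc(-c2nn(-c3ccccc3)cc2-c2nc3cc(F)ccc3[nH]2)cc1` gives 1510 nM. Compound 3 stands level with compound 1, as the methoxy in place of fluoro exchange gives a 1.6-fold higher number from compound 1 to compound 3 (0.20 log units; within the scatter). Its number lies under that of compound 2, so it sits at the better end of this small set, without being separable from compound 1.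

Compound 4 `COc1ccc(-c2nn(-c3ccccc3)cc2-c2nc3cc(Br)ccc3[nH]2)cc1` follows from compound 3 by a single exchange, bromo in place of fluoro on an aromatic carbon of a six-membered aromatic ring of carbon only, part of a fused or bridged system of two rings: bromo in place of fluoro on an aromatic carbon.

The same exchange has been measured once, and that measurement gave a 3.4-fold higher number from compound 1 to compound 2 (0.53 log units; beyond the scatter), a modest step but beyond the scatter. For the measured compounds named here, it was seen with fluoro where compound 3 carries methoxy, and no measured pair yet shows whether it carries over unchanged. The size is therefore taken slightly smaller than that single precedent, in the same direction, towards weaker inhibition. The expected step in this assay is a 2.8-fold higher number from compound 3 to compound 4 (0.45 log units; beyond the scatter).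

The estimate for compound 4 is 4300 nM, with an expected range of 2200 nM to 8500 nM.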

Compound 4, half-maximal inhibitory concentration: 1830 nM
Beside the measured number, compound 4's estimate is 2.3-fold (0.37 log units) above it; the measured number lies below the stated range.
By their numbers in this assay, from the lowest: compounds 1, 3, 4 and 2 (each within the scatter of the next, the first and the last beyond it).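

The size of the bromo in place of fluoro exchange on this aromatic carbon is not fixed: with methoxy in the molecule it gives a 1.2-fold higher number from compound 3 to compound 4 (0.08 log units; within the scatter), so the step seen with fluoro does not carry over, and the two cores differ clearly: the same change on two cores in this assay, a 3.4-fold higher number (0.53 log units; beyond the scatter) from compound 1 to compound 2 and a 1.2-fold higher number (0.08 log units; within the scatter) from compound 3 to compound 4, 2.8-fold (0.45 log units) apart, beyond the scatter of two such steps. The methoxy in place of fluoro exchange, read on the bromo compounds, gives a 1.8-fold lower number from compound 2 to compound 4 (0.24 log units; within the scatter), which is within the scatter on its own but differs in direction from the step on the fluoro compounds, and the gap between the two is larger than the scatter: the same change on two cores in this assay, a 1.6-fold higher number (0.20 log units; within the scatter) from compound 1 to compound 3 and a 1.8-fold lower number (0.24 log units; within the scatter) from compound 2 to compound 4, 2.8-fold (0.45 log units) apart, beyond the scatter of two such steps. For the compounds shown here, the two exchanged places therefore do not act independently in these four compounds, and among their four single-exchange steps, only the one joining compound 1 and compound 2 lies beyond the scatter.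

This dependence rests on a single square of four compounds, and a cell read-out of this kind gives no cause for it. As far as these compounds go, it remains open whether chloro or a plain hydrogen at this aromatic carbon, or ethoxy or a dimethylamino group in place of the methoxy, would follow the fluoro or the methoxy pattern.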